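Dichloroacetamide biphenyls: methyl for trifluoromethyl on the outer ring

The source may report more compounds than this note shows. Statements on the series, on what has been measured and on what is new or still open speak of the compounds shown alone.

Three members of this series have been tested so far, all built on a shared core bearing a dichloroacetamide. Compound 1 `Cc1ccc(-c2cccc(NC(=O)C(Cl)Cl)c2)cc1` carries a methyl group on the outer ring, while compound 2 `O=C(Nc1cccc(-c2cccc(C(F)(F)F)c2)c1)C(Cl)Cl` and compound 3 `O=C(Nc1cccc(-c2ccc(C(F)(F)F)cc2)c1)C(Cl)Cl` carry a trifluoromethyl group there. In a functional assay on A549 cells (Homo sapiens) for cytotoxicity, read by MTT assay, with a stated time of 68 h (on this read-out higher numbers stand for weaker inhibition and lower numbers for stronger inhibition), compound 1 gives 8300 nM. In this assay compound 2 gives 18500 nM, and compound 3 gives 23500 nM. Compound 2 and compound 3 have the same atoms joined differently; the difference between the two cores is not broken down here, and their two values lie within the scatter of each other.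

One counted step is available, from compound 3 to compound 1: methyl in place of trifluoromethyl on an aromatic carbon. It produced a 2.8-fold lower number from compound 3 to compound 1 (0.45 log units; beyond the scatter).

Compound 4 `Cc1cccc(-c2cccc(NC(=O)C(Cl)Cl)c2)c1` remains to be measured. Against compound 2 it shows (methyl in place of trifluoromethyl on an aromatic carbon). This is the same kind of change as that from compound 3 to compound 1; the place descriptions differ only in that the group in compound 4 stands meta to a large group, whereas in compound 1 it stands para to a large group. Because of a 2.8-fold lower number from compound 3 to compound 1 (0.45 log units; beyond the scatter), a step of about a 2.6-fold lower number from compound 2 to compound 4 (0.42 log units; beyond the scatter) is expected in this assay, starting from compound 2 at 18500 nM. Compound 4 is therefore estimated at 7000 nM, with a likely range from 3000 nM to 16000 nM.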

Compound 4, half-maximal inhibitory concentration: 8700 nM
For compound 4 the middle estimate is 1.2-fold (0.09 log units) below the measured one, and the stated range covers the measured number.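

In this assay, methyl in place of trifluoromethyl on an aromatic carbon, here meta to a large group, gave a 2.1-fold lower number from compound 2 to compound 4 (0.33 log units; beyond the scatter). Set beside the earlier step, the change carries over from one core to the other, in the same direction and with no difference in size that stands out from the scatter: the same change on two cores in this assay, a 2.8-fold lower number (0.45 log units; beyond the scatter) from compound 3 to compound 1 and a 2.1-fold lower number (0.33 log units; beyond the scatter) from compound 2 to compound 4, 1.3-fold (0.12 log units) apart, within the scatter of two such steps. This supports using the step as a working estimate between these two cores only; it rests on two modest steps in a single cell assay, and it shows neither how the change would behave on any other core nor why the number falls.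

The compounds shown leave open whether other groups on the outer ring, such as a chlorine, a methoxy group, an amine or a carboxylic acid, would give numbers in line with methyl or with trifluoromethyl. All four compounds carry the dichloroacetamide, so they also leave open how the series would respond to a plain acetamide or a trichloroacetamide in its place, and whether the methyl step would hold there.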